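This account rests on a few compounds, and the source may have more. Where it says the series, first, only, none or still open, it means among the compounds named here.

In an ADME assay on MT4 cells (Homo sapiens) for cytotoxicity, read by MTT assay, with a stated time of 96 h (a higher number here means that more compound is tolerated, a lower number that less compound is tolerated), measured so far:
- compound 1 `NS(=O)(=O)c1ccc(N2N=C(c3ccccc3)CC2c2ccccc2Cl)cc1`: 44000 nM
- compound 2 `NS(=O)(=O)c1ccc(N2N=C(c3ccc(OCc4ccccc4)cc3)CC2c2ccccc2)cc1`: > 100000 nM
- compound 3 `Cc1cccc(C2CC(c3ccc(Oc4ccccc4)cc3)=NN2c2ccc(S(N)(=O)=O)cc2)c1`: 35000 nM

Compound 2 stands at > 100000 nM, which is a limit of the assay and not a number. Compound 4 `NS(=O)(=O)c1ccc(N2N=C(c3ccc(OCc4ccccc4)cc3)CC2c2ccc(Cl)cc2)cc1` follows from compound 2 with one change, chloro in place of hydrogen on an aromatic carbon. Going by the values given here, no measured step isolates this change. The two compounds with numbers both carry a substituent on the corresponding phenyl ring, but they also differ from compound 2 elsewhere: compound 1 gives 44000 nM and compound 3 gives 35000 nM. On that basis, a modest step towards less compound tolerated is expected, estimated as an at least 1.8-fold lower number from compound 2 to compound 4 (0.25 log units; that floor lies within the scatter). Compound 4 is expected at 55000 nM, with an estimated range of 25000 nM to 100000 nM.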

Compound 4, half-maximal cytotoxic concentration: 70000 nM
Beside the measured number, compound 4's estimate is 1.3-fold (0.10 log units) below it; measured number inside the range.
By their numbers in this assay, from the lowest: compounds 3, 1 and 4 (each within the scatter of the next). At a limit, above all of these: compound 2.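

In this assay, going by these compounds alone, the phenyl to 4-chlorophenyl change gives the first step that isolates this position: an at least 1.4-fold lower number from compound 2 to compound 4 (0.15 log units; that floor lies within the scatter). Compound 2 stands at > 100000 nM, which is a limit of the assay and not a number, so the full size of the step stays unknown: the limit of > 100000 nM in this assay, at which 1 of the 4 values shown sits.
Compound 4 gives 70000 nM, a number at this position, yet the step does not establish a real drop.

Open, on these data alone, is how a methoxy, an amine or a carboxylic acid on the same carbon would compare with chloro. Also open, as far as these compounds go, is whether the same change gives a similar step elsewhere.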